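Swapping bromo for iodo on a weak sulfonamide series

This account rests on a few compounds, and the source may have more. Where it says the series, first, only, none or still open, it means among the compounds named here.

Measured so far:
- compound 1, `O=C(c1ccccc1)c1ccc(NS(=O)(=O)c2ccc(Cl)cc2Cl)cc1`: 20000 nM
- compound 2, `Cc1ccc(S(=O)(=O)Nc2ccc(C(=O)c3ccccc3)cc2)cc1`: "not active" (no number reported)
- compound 3, `O=C(c1ccccc1)c1ccc(NS(=O)(=O)c2ccc(Br)cc2)cc1`: "not active" (no number reported)

All three share the same core, a benzophenone carrying a sulfonamide whose second aryl ring varies. Within the data shown here, in an assay on CHO cells for binding affinity to integrin alpha-1 (Homo sapiens), read by WST assay, with a stated time of 2 h (a higher number here means that more compound is needed for the effect, a lower number that less compound is needed), compound 1 gives 20000 nM, the only value in this set that is an actual number. In this assay compound 2 is reported as "not active" (no number reported), with no number attached. In this assay compound 3 likewise comes back as "not active" (no number reported), so it stands without a single number, and it shares that position with compound 2. No comparison between any two of these compounds can therefore be put into a size.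

Compound 4, `O=C(c1ccccc1)c1ccc(NS(=O)(=O)c2ccc(I)cc2)cc1`, is the next member. Its difference from compound 3 is iodo in place of bromo on an aromatic carbon, a small change of one halogen for another. With compound 3 giving no number at all, there is no shown step to lean on; the expectation is that this assay will again give either no number or a value in the same weak region as compound 1.

In this assay compound 4 is expected to give roughly 30000 nM, with a plausible range from 8000 nM to 100000 nM.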

Compound 4, half-maximal effective concentration: 22000 nM
Beside the measured number, compound 4's estimate is 1.4-fold (0.13 log units) above it; measured number inside the range.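

In this assay compound 4 returns a number, so a 4-iodophenyl group on the sulfonyl sulfur is compatible with a measurable value, while compound 3, with 4-bromophenyl at the same place, is reported only as not active; the step between these two cannot be read, since one side has no number. Exchanging 2,4-dichlorophenyl for 4-iodophenyl on the sulfonyl sulfur gives a 1.1-fold higher number from compound 1 to compound 4 (0.04 log units; within the scatter) and this lies within the scatter, so the assay does not separate these two groups, and a single halogen para to the large group can give a value at the same weak level as two chlorines. No measurement is available to explain why the iodo compound gives a number and the bromo compound does not.

Open, from the compounds shown here alone, is whether a different kind of group at that same place, such as an amine or a carboxylic acid, would give a much lower number than this weak level. Also open, going by these compounds, is whether any change to the shared core, rather than to this aryl ring, would move the number beyond the scatter.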